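Swapping a Piperidine Amide for a Quinoline

The source may report more compounds than this note shows. Statements on the series, on what has been measured and on what is new or still open speak of the compounds shown alone.

Of the compounds shown here, three have been measured in a physicochemical assay for solubility, in phosphate buffer, at pH 7.4; on this read-out lower numbers stand for lower solubility and higher numbers for higher solubility. Compound 1 `OCC1CCN(c2nccnc2Oc2ccc(Nc3nc4ccccc4s3)cc2)CC1` gives 6000 nM, compound 2 `OCC1CCN(c2nccnc2OC2CN(c3nc4ccccc4s3)C2)CC1` gives 31000 nM, and compound 3 `NC(=O)C1CCN(c2nccnc2OC2CN(c3ccc4ccccc4n3)C2)CC1` gives 14000 nM. Among these three numbers compound 3 stands second highest: compound 2 sits higher and compound 1 sits lower, and both of these gaps are beyond the usual scatter of this assay.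

Compound 4 `c1ccc2ncc(-c3nccnc3OC3CN(c4ccc5ccccc5n4)C3)cc2c1` has not yet been measured. It differs from compound 3 in one place: quinolin-3-yl in place of 4-carbamoylpiperidin-1-yl on an aromatic carbon. The group that leaves carries one hydrogen-bond donor and two hydrogen-bond acceptors on a six-membered non-aromatic ring; the group that enters brings two six-membered aromatic rings, no hydrogen-bond donors and one hydrogen-bond acceptor.

For the measured compounds named here, no measured pair in this set shows the same change, so the expectation rests on the change itself. The step of a 14-fold lower number from compound 3 to compound 4 (1.15 log units; beyond the scatter) is expected to be a drop well beyond the scatter. Compound 4 is therefore estimated to give 1000 nM, within a range from 200 nM to 5000 nM.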

Compound 4, solubility: < 1000 nM
Compound 4 was reported as a limit (the forecaster's own chance of this, stated with the estimate: 15%); the middle value sits exactly at the limit.
By their numbers in this assay, from the lowest: compound 1; then compound 3; then compound 2. At a limit, below all of these: compound 4.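

In this assay, putting quinolin-3-yl in place of 4-carbamoylpiperidin-1-yl on this aromatic carbon gives an at least 14-fold lower number from compound 3 to compound 4 (1.14 log units; beyond the scatter). The earlier compounds shown here differ from each other in more than one place, so they could not show that a change at this position alone moves the read-out, and this pair shows that it can. The reading for compound 4 is a limit and not a number: the limit of < 1000 nM in this assay, at which 1 of the 4 values shown sits.

This single pair leaves open which part of the change matters, whether the departure of the amide, the departure of the saturated ring or the arrival of the quinoline. Also open, on these data alone, is how a piperidine bearing a carboxylic acid, or a small amine such as dimethylamino, would read at this same place.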